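The compounds below may be only part of what the source reports. "The series", "measured", "known", "first", "only" and "open" are said of these compounds alone.

Series notes. Compound 1 `O=C(N1CCCN(Cc2ccc(OCc3ccccc3)cc2)CC1)n1cccn1` in an assay on membranes from brain for binding affinity to neutral cholesterol ester hydrolase 1 (Mus musculus), read by fluorescence, with stated times of 1 h and 30 min (on this read-out lower numbers stand for stronger inhibition and higher numbers for weaker inhibition), returns only a limit, > 100000 nM. Compound 2 `N#Cc1cnn(C(=O)N2CCCN(Cc3ccc(OCc4ccccc4)cc3)CC2)c1` likewise returns only a limit in this assay, > 100000 nM. The change between the two is cyano in place of hydrogen on an aromatic carbon, and the step that the two limits leave unreadable from compound 1 to compound 2 cannot be sized, since both values sit on (the limit of > 100000 nM in this assay, at which 3 of the 3 values shown sit). Compound 3 `CN(CCN(C)C(=O)n1cccn1)Cc1ccc(OCc2ccccc2)cc1` carries another core; the difference between the core of compound 1 and the core of compound 3 is not broken down here. In this assay compound 3 also returns only a limit, > 100000 nM. Compound 4 `CN(CCN(C)C(=O)n1cc(C#N)cn1)Cc1ccc(OCc2ccccc2)cc1` arises from compound 3 by the same change, (cyano in place of hydrogen on an aromatic carbon), at a place that reads the same in both pairs. Beside the unreadable a step that the two limits leave unreadable from compound 1 to compound 2, the expected step that the limit leaves unreadable from compound 3 to compound 4 is small, resting on (the limit of > 100000 nM in this assay, at which 3 of the 3 values shown sit). Compound 4 is expected near 150000 nM in this assay, most likely again as a limit.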

Compound 4, half-maximal inhibitory concentration: > 100000 nM
Compound 4: only a limit was reported; the forecaster's own chance of this, stated with the estimate: 85%; the middle value lies beyond the limit too.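

No new step can be read from compound 3 to compound 4, as both return only a limit: the limit of > 100000 nM in this assay, at which 4 of the 4 values shown sit. The compounds shown leave open how large the effect of cyano in place of hydrogen is on either core.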